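Trimming the Benzyl Group from an Oxime Ether

The source may hold more compounds than are shown below. What is called first, only, known or untested is meant among the compounds shown, and "the series" means these compounds.

Of the compounds shown here, two of a shared core have been measured so far. Compound 1 `CC(C)n1nc(-c2ccon2)c2c(N)ncnc21` gives, in an assay on BaF3 cells for inhibition of proto-oncogene tyrosine-protein kinase receptor Ret (Homo sapiens), read by MTT assay, with a stated time of 48 h (a higher number here means a weaker inhibitor of growth, a lower number a stronger inhibitor of growth), a value of 3210 nM. Compound 2 `CC(C)n1nc(/C=N/OCc2ccccc2)c2c(N)ncnc21` gives in this assay 7410 nM, the higher of the two numbers; the gap to compound 1 lies beyond the usual scatter, so compound 2 is the weaker growth inhibitor of the pair.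

Compound 3 `CC(C)n1nc(/C=N/O)c2c(N)ncnc21` has not yet been measured. It differs from compound 2 in one place: hydrogen in place of benzyl on an oxygen. For the measured compounds named here, no measured pair shows this exact change, so its effect can only be guessed. Removing seven carbon atoms is a sizeable cut, and with nothing in the measured set to anchor it, a modest step toward a higher number seems the more likely outcome, though a step in the other direction cannot be ruled out.

The expected step from compound 2 to compound 3 in this assay is a 1.3-fold higher number from compound 2 to compound 3 (0.13 log units; within the scatter). Compound 3 is therefore estimated at 10000 nM, with a likely range from 3000 nM to 30000 nM.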

Compound 3, concentration for 50% growth inhibition: > 10000 nM
Compound 3 was reported as a limit; the forecaster's own chance of this, stated with the estimate: 20%; the middle value sits exactly at the limit.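

Compound 3 is reported in this assay only as a limit of the assay, not as a number: the limit of > 10000 nM in this assay, at which 1 of the 3 values shown sits. Hydrogen in place of benzyl on this oxygen gives an at least 1.3-fold higher number from compound 2 to compound 3 (0.13 log units; that floor lies within the scatter), and since that floor lies within the scatter, the true step may be small or large, but the bare oxime shows no gain in growth inhibition over its benzyl ether. On the aromatic carbon of the shared core, a group of 3 heavy atoms in place of a group of 5 heavy atoms that holds a five-membered aromatic ring gives an at least 3.1-fold higher number from compound 1 to compound 3 (0.49 log units; beyond the scatter), which is beyond the scatter and marks the bare oxime as clearly the weaker growth inhibitor of that pair.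

From the compounds shown here alone, how far compound 3 truly lies from compound 2 cannot be read from a limit, so the full weight of the benzyl group at this oxygen remains unknown. Also open, going by these compounds, is whether something between hydrogen and benzyl on the same oxygen, such as a methyl group or a longer chain, would give a lower number in this assay.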